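Ring size at the aromatic carbon: from cyclopentyl to cyclohexyl

The source may report more compounds than this note shows. Statements on the series, on what has been measured and on what is new or still open speak of the compounds shown alone.

Measured compounds:
Compound 1 `O=c1cc(C2CCCCC2)oc2ccc(OCCCCCCN3CCC(O)CC3)cc12`: 88 nM
Compound 2 `O=c1cc(C2CCC2)oc2ccc(OCCCCCCN3CCCCC3)cc12`: 51 nM
Compound 3 `O=c1cc(C2CCCC2)oc2ccc(OCCCCCCN3CCCCC3)cc12`: 26 nM

In an assay on isolated protein (Cavia porcellus) with Sigma non-opioid intracellular receptor 1 (Homo sapiens) as the target, read by radioligand binding (a lower number here means a stronger inhibitor, a higher number a weaker inhibitor), compound 3 gives the lowest of the three numbers; compound 2 lies nearest, within the scatter, while compound 1 lies beyond it. Compound 4 `O=c1cc(C2CCCCC2)oc2ccc(OCCCCCCN3CCCCC3)cc12` is not yet measured and differs from compound 3 by cyclohexyl in place of cyclopentyl on an aromatic carbon. For the measured compounds named here, the one step that bears on this change is a 2.0-fold lower number from compound 2 to compound 3 (0.29 log units; within the scatter), which stayed within the scatter. Going by the values given here, compound 1 also carries a cyclohexyl but differs from compound 4 elsewhere as well, so its value shows only that a cyclohexyl compound can still sit near this range. Compound 4 is therefore expected to show a 1.3-fold lower number from compound 3 to compound 4 (0.11 log units; within the scatter), no change beyond the scatter, with an estimate of 20 nM ranging from 8 nM to 60 nM.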

Compound 4, half-maximal inhibitory concentration: 55 nM
For compound 4 the middle estimate is 2.8-fold (0.44 log units) below the measured one; the measured number falls inside the stated range.
By their numbers in this assay, from the lowest: compounds 3, 2, 4 and 1 (each within the scatter of the next, the first and the last beyond it).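

In this assay, for the compounds shown here, enlarging the ring at this aromatic carbon gives the first step beyond the scatter, though a modest one (a 2.1-fold higher number from compound 3 to compound 4 (0.33 log units; beyond the scatter)). Cyclohexyl and cyclobutyl cannot be told apart (a 1.1-fold higher number from compound 2 to compound 4 (0.03 log units; within the scatter)), so across the three ring sizes only cyclopentyl and cyclohexyl are separated. Hydrogen in place of hydroxy on the saturated ring carbon also leaves the two cyclohexyl compounds within the scatter (a 1.6-fold lower number from compound 1 to compound 4 (0.20 log units; within the scatter)). On these data alone, how a phenyl ring or an isopropyl group at this aromatic carbon would compare remains open. No evidence explains these steps.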